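A few compounds are considered here, and "the series" means these few. Any claim that something is new, unique, unknown or untested is made for them only; others in the source may bear on it.

Measured compounds, with their values in an assay on BaF3 cells for inhibition of thrombopoietin receptor (Homo sapiens), tested at 150 nM; a lower number here means a weaker effect, a higher number a stronger effect of the compound at the concentration tested:
compound 1 `C/C(NNC(=S)N1CCc2cc(C(=O)O)ccc21)=C1/C(=O)N(c2ccc3c(c2)CCC3)c2ccccc21` gives 14.3%
compound 2 `C/C(NNC(=S)N1CCc2cc(C(=O)O)ccc21)=C1/C(=O)N(c2ccc(C)cc2)c2ccc(F)cc21` gives 78.1%
compound 3 `C/C(NNC(=S)N1CCCc2cc(C(=O)O)ccc21)=C1/C(=O)N(c2ccc(C)c(C)c2)c2ccccc21` gives 30.9%

Among these three, compound 3 stands second highest in this assay. Its nearest neighbour is compound 1, whose number is lower by a margin beyond the usual scatter; its furthest is compound 2, whose number is higher by a margin well beyond the scatter. For the measured compounds named here, no step between any two measured compounds is computed here, as each pair differs in more than one place.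

Compound 4 `C/C(NNC(=S)N1CCCc2cc(C(=O)O)ccc21)=C1/C(=O)N(c2ccc(C)cc2)c2ccccc21` has not yet been measured. It differs from compound 3 by hydrogen in place of methyl on an aromatic carbon, that is, 3,4-dimethylphenyl to 4-methylphenyl. Compound 2 also carries 4-methylphenyl, but differs from compound 4 in two further places. The value of compound 2, 78.1%, therefore cannot be read as a guide. The change is small, and compound 4 is expected to show a number 7.1 percentage points higher from compound 3 to compound 4 (within the scatter), a step within the scatter or slightly upward. Compound 4 is estimated at 38%, with a range from 18% to 62%.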

Compound 4, a percentage reported as inhibition, at one concentration (the size of the read-out at that concentration, not a potency): 47.3%
For compound 4 the middle estimate is 9.3 percentage points below the measured one; measured number inside the range.
By their numbers in this assay, from the lowest: compound 1; then compound 3; then compound 4; then compound 2.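

In this assay, the change from 3,4-dimethylphenyl to 4-methylphenyl, hydrogen in place of methyl on an aromatic carbon, gives a number 16.4 percentage points higher from compound 3 to compound 4 (beyond the scatter). For the compounds shown here, this is the first comparison that differs in only one place, and it shows that the read-out at this concentration does not depend on keeping this methyl: with hydrogen at this position, the number rises beyond the usual scatter. Nothing available bears on why the number rises.

As far as these compounds go, whether a methoxy group, a chlorine atom or an amine at this position would give a higher or lower number stays open, as this single step compares only methyl with hydrogen. From the compounds shown here alone, whether the same step would appear on the core of compound 2 also stays open.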